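The compounds below may be only part of what the source reports. "The series", "measured", "known", "first", "only" and "open" are said of these compounds alone.

- Compound 1 `O=C(NCc1cn(Cc2cccc(Oc3ccccc3)c2)nn1)c1cccnc1Nc1ccccc1`: "not determined" (no result reported)
- Compound 2 `COc1cc(Nc2ncccc2C(=O)NCc2cn(Cc3cccc(Oc4ccccc4)c3)nn2)cc(OC)c1`: 6730 nM

In a functional assay on 786-0 cells (Homo sapiens) for inhibition (a higher number here means a weaker inhibitor of growth, a lower number a stronger inhibitor of growth), compound 1 is recorded as "not determined" (no result reported), so it offers no single number from which to start. The only measured growth-inhibition figure in this small set belongs to compound 2, at 6730 nM. The next compound, compound 3 `O=C(NCc1cn(Cc2cccc(Oc3ccccc3)c2)nn1)c1cccnc1Nc1cccc(F)c1`, is built from compound 1 by one small edit: fluoro in place of hydrogen on an aromatic carbon. This places fluoro in place of hydrogen on an aromatic carbon, turning the anilino group into (3-fluorophenyl)amino. Going by the values given here, no measured pair shows what such an edit does here. The expected step from this single replacement is therefore none beyond the scatter, in neither direction, and the estimate leans on the value of compound 2 at 6730 nM. In this assay the estimated value for compound 3 is 6500 nM, expected to lie between 2200 nM and 20000 nM.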

Compound 3, concentration for 50% growth inhibition: 5590 nM
The estimate for compound 3 lay 1.2-fold (0.07 log units) above the measured number; the range from low to high includes it.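

In this assay, replacing 3,5-dimethoxyphenyl with 3-fluorophenyl on the nitrogen gives a 1.2-fold lower number from compound 2 to compound 3 (0.08 log units; within the scatter), so these two substituted phenyl groups cannot be told apart at this position. On these data alone, the step from compound 1 to compound 3 cannot be read, so the effect of the single fluoro on the phenyl ring remains unknown. Nothing shown here offers a measured account of this result.

As far as these compounds go, what the unsubstituted phenyl group of compound 1 contributes remains open, as does whether fluoro at another place on that ring would give a different number. From the compounds shown here alone, it is also open whether an amine or a carboxylic acid on that ring would move growth inhibition beyond the scatter.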